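The source may report more compounds than this note shows. Statements on the series, on what has been measured and on what is new or still open speak of the compounds shown alone.

Two compounds from the series have been run in a functional assay on UACC-62 cells (Homo sapiens) for cytotoxicity, read by sulforhodamine B assay, with a stated time of 48 h, tested at 0.01 uM (a higher number here means a weaker effect of the compound at the concentration tested, a lower number a stronger effect), so far. Compound 1 `COc1ccc(-c2cc(/C=C/C(=O)c3ccc(N)cc3)[nH]n2)cc1` gives 96% in this assay. Compound 2 `COc1cc(-c2cc(/C=C/C(=O)c3ccc(Cl)c(Cl)c3)[nH]n2)cc(OC)c1OC` gives 97% in this assay, and on these two numbers compound 2 stands alongside compound 1, the gap between them lying within the usual scatter of repeated measurements, so neither can be called the weaker or the stronger of the pair.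

The next compound, compound 3 `COc1ccc(C(=O)/C=C/c2cc(-c3cc(OC)c(OC)c(OC)c3)n[nH]2)cc1`, differs from compound 2 in a single place: 4-methoxyphenyl in place of 3,4-dichlorophenyl on a carbonyl carbon. Within the data shown here, no step between two measured compounds that differ in one place is available, so there is nothing from which to read off how large an effect such a change tends to have here. What the two measured compounds do show is that both, with their different aryl groups on the carbonyl carbon, give high numbers at this concentration. On that basis the step from compound 2 to compound 3 is expected to be a number 1 percentage points lower from compound 2 to compound 3 (within the scatter), no larger than the scatter, in no set direction. Compound 3 is therefore estimated to give 96% in this assay, within a range from 86% to 104%.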

Compound 3, a percentage reported as activity, at one concentration (the size of the read-out at that concentration, not a potency): 100%
Estimate against measurement, compound 3: 4 percentage points below, and the stated range covers the measured number.
By their numbers in this assay, from the lowest: compounds 1, 2 and 3 (each within the scatter of the next).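

In this assay, among these compounds, 4-methoxyphenyl in place of 3,4-dichlorophenyl on a carbonyl carbon gives a number 3 percentage points higher from compound 2 to compound 3 (within the scatter), the first step that can be read at this position. At this concentration, the two compounds cannot be told apart, although the change removes both chlorine atoms and brings in an oxygen and a hydrogen-bond acceptor. No measurement here bears on why the read-out stays within the scatter across this change.

From the compounds shown here alone, since the step was read at a single concentration, where both compounds give high numbers, it remains open whether the two aryl groups would also match at higher concentrations, where a difference between them might appear. Going by these compounds, it is also open whether a more different group on the carbonyl carbon, such as a cyclohexyl ring or a phenyl ring carrying a carboxylic acid, would move the number beyond the scatter in this assay.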